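The compounds below may be only part of what the source reports. "The series", "measured", "known", "first", "only" and "open" are said of these compounds alone.

Measured so far in a functional assay on the whole organism (blood) with Rattus norvegicus as the target, with stated times of 24 h and 1 h, at a dose of 15 mg/kg by the intraperitoneal route; on this read-out higher numbers stand for a stronger effect at the one dose given and lower numbers for a weaker effect:

compound 1 `Cn1cc(C(=O)NCCC2CCN(S(=O)(=O)NC(=O)NC3CCCCC3)CC2)c(=O)n(C)c1=O` — 15%
compound 2 `COc1ccc(C(=O)NCCC2CCN(S(=O)(=O)NC(=O)NC[C@@H]3C[C@@H]4C=C[C@@H]3C4)CC2)cn1` — 32%

On these two numbers compound 2 stands highest; compound 1 lies lower by a gap beyond the usual scatter. Compound 3 `O=C(NC[C@@H]1C[C@@H]2C=C[C@@H]1C2)NS(=O)(=O)N1CCC(CCNC(=O)c2cccc3c2OCCO3)CC1` is not yet measured. Relative to compound 2 it carries one change: 2,3-dihydro-1,4-benzodioxin-5-yl in place of 6-methoxypyridin-3-yl on a carbonyl carbon. Within the data shown here, no measured pair shows this change, so its size is unknown; the expected step in this assay is small, within the scatter, with a slight downward lean. Compound 3 is expected to give about 28%, from 10% to 45%. The estimated step is a number 4 percentage points lower from compound 2 to compound 3 (within the scatter).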

Compound 3, a percentage reported as activity, at one dose (the size of the read-out at that dose, not a potency): 40%
Estimate against measurement, compound 3: 12 percentage points below, and the stated range covers the measured number.
By their numbers in this assay, from the lowest: compound 1; then compounds 2 and 3 (each within the scatter of the next).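

On a carbonyl carbon whose other neighbour is an amide-type nitrogen, 2,3-dihydro-1,4-benzodioxin-5-yl replaces 6-methoxypyridin-3-yl with no readable change in this assay, the step being a number 8 percentage points higher from compound 2 to compound 3 (within the scatter). This position therefore accepts a group with no ring nitrogen and an added non-aromatic ring, at the same count of hydrogen-bond acceptors.

As far as these compounds go, it remains open whether a plain phenyl or a group carrying an amine or a carboxylic acid would also hold the read-out at this position. No measurement here offers an explanation for the result.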